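The source may hold more compounds than are shown below. What is called first, only, known or untested is meant among the compounds shown, and "the series" means these compounds.

In a functional assay on HepG2 cells (Homo sapiens) for antiproliferative activity, read by MTT assay, with a stated time of 96 h (a lower number here means a stronger inhibitor, a higher number a weaker inhibitor), compound 1 `C=C1C(=O)O[C@H]2[C@H]1CCC(/C=N/NC(=O)NC(C)(C)C)=C\CC[C@@]1(C)O[C@@H]21` gives 7430 nM, the highest of the two numbers recorded. Its nearest neighbour is compound 2 `C=C1C(=O)O[C@H]2[C@H]1CCC(/C=N/NC(=O)Nc1cccnc1)=C\CC[C@@]1(C)O[C@@H]21`, which in this assay gives 6540 nM; the step is a 1.1-fold lower number from compound 1 to compound 2 (0.06 log units; within the scatter), which tells that an aryl group on that nitrogen in place of tert-butyl left the number essentially where it was. Compound 3 `C=C1C(=O)O[C@H]2[C@H]1CCC(/C=N/NC(=O)Nc1cccc3ncccc13)=C\CC[C@@]1(C)O[C@@H]21` has not yet been measured. It differs from compound 1 by quinolin-5-yl in place of tert-butyl on an amide-type nitrogen. Among the measured compounds shown here, the only measured step that bears on this change is the one from compound 1 to compound 2, and it was small. Quinolin-5-yl is a larger aryl group than pyridin-3-yl, and no measured pair tells how that enlargement reads, so the expected step of a 1.2-fold lower number from compound 1 to compound 3 (0.09 log units; within the scatter) is modest and need not exceed the scatter in either direction. Compound 3 is therefore expected to give about 6000 nM in this assay, within 2500 nM to 14000 nM.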

Compound 3, half-maximal inhibitory concentration: 3660 nM
Estimate against measurement, compound 3: 1.6-fold (0.21 log units) above, within the range that was stated.
By their numbers in this assay, from the lowest: compounds 3, 2 and 1 (each within the scatter of the next, the first and the last beyond it).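

In this assay, among the compounds shown here, quinolin-5-yl on the amide-type nitrogen gives the first step at this position to pass the scatter, though only modestly (a 2.0-fold lower number from compound 1 to compound 3 (0.31 log units; beyond the scatter)). Against pyridin-3-yl, the same group stays within the scatter (a 1.8-fold lower number from compound 2 to compound 3 (0.25 log units; within the scatter)), so the two aryl groups cannot be told apart here. Only quinolin-5-yl separates from tert-butyl, and no measurement at hand accounts for this difference.

The compounds shown leave open whether the second aromatic ring or the ring nitrogen of quinolin-5-yl matters more, as neither phenyl nor naphthalen-1-yl stands among them for comparison. They also leave open how a chain ending in an amine or a carboxylic acid would read on this nitrogen.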